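This account rests on a few compounds, and the source may have more. Where it says the series, first, only, none or still open, it means among the compounds named here.

In a functional assay on MCF7 cells (Homo sapiens) for antiproliferative activity, read by MTT assay, with a stated time of 72 h (on this read-out higher numbers stand for weaker inhibition and lower numbers for stronger inhibition), compound 1 `O=C(N/N=C/c1ccccn1)c1cccc(S(=O)(=O)N2CCOCC2)c1` shows > 100000 nM, which is a limit of the assay and not a number. Compound 2 `O=C(N/N=C/c1ccccc1O)c1cccc(S(=O)(=O)N2CCOCC2)c1` gives 29100 nM. Compound 3 `COc1ccc(/C=N/NC(=O)c2cccc(S(=O)(=O)N3CCOCC3)c2)c(O)c1` gives 5140 nM, the lowest number of the set so far and therefore the strongest inhibition. Compound 4 `O=C(N/N=C/c1cc(Cl)ccc1O)c1cccc(S(=O)(=O)N2CCOCC2)c1` is still unmeasured, and it differs from compound 3 in one group: 5-chloro-2-hydroxyphenyl in place of 2-hydroxy-4-methoxyphenyl on a carbon with a double bond to nitrogen.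

Within the data shown here, two measured steps bear on this change. Putting 2-hydroxyphenyl in place of pyridin-2-yl gave an at least 3.4-fold lower number from compound 1 to compound 2 (0.53 log units; beyond the scatter), and compound 4 keeps a hydroxy group. Methoxy in place of hydrogen on an aromatic carbon gave a 5.7-fold lower number from compound 2 to compound 3 (0.75 log units; beyond the scatter), a modest step, and that methoxy is gone in compound 4, so part of this gain may be lost. Among the measured compounds shown here, no measured compound carries chlorine, so its contribution is unknown. A modest move towards a higher number is therefore expected in this assay. The estimated change is a 1.8-fold higher number from compound 3 to compound 4 (0.24 log units; within the scatter). For compound 4 the expected value is 9000 nM, with an estimated range from 2500 nM to 30000 nM.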

Compound 4, half-maximal inhibitory concentration: 16500 nM
Compound 4: the middle estimate sits 1.8-fold (0.26 log units) below what was measured; low and high end bracket the measured number.
By their numbers in this assay, from the lowest: compound 3; then compounds 4 and 2 (each within the scatter of the next). At a limit, above all of these: compound 1.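

In this assay, chloro in place of hydrogen gives a 1.8-fold lower number from compound 2 to compound 4 (0.25 log units; within the scatter), so the data do not separate compounds 2 and 4 and show no measurable gain from this chloro group. Exchanging the whole ring substituent pattern gives a 3.2-fold higher number from compound 3 to compound 4 (0.51 log units; beyond the scatter), so the 5-chloro-2-hydroxyphenyl group does not match the 2-hydroxy-4-methoxyphenyl group at this place, and among the compounds shown only the methoxy step on the hydroxyphenyl ring lies beyond the scatter. The step of an at least 6.0-fold lower number from compound 1 to compound 4 (0.78 log units; beyond the scatter) starts from a limit and not a number, so it gives only a bound on the gain over pyridin-2-yl: the limit of > 100000 nM in this assay, at which 1 of the 4 values shown sits.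

From the compounds shown here alone, it remains open whether chloro and methoxy together on one ring would differ from either alone. Whether bromo or an amine would do better at this place is also unknown.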